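Working notes: aryl replacement on the shared core

This account rests on a few compounds, and the source may have more. Where it says the series, first, only, none or still open, it means among the compounds named here.

compound 1 `O=C(NO)c1ccc(NCc2nc(-c3cccnc3)nn2-c2ccccc2)cc1` — 57.7%
compound 2 `O=C(O)c1ccc(NCc2nc(-c3ccccc3)nn2-c2ccccc2)cc1` — -0.4%
compound 3 `NC(=O)c1ccc(NCc2nc(-c3ccccc3)nn2-c2ccccc2)cc1` — -4.4%

In an assay on Sf9 cells for inhibition of protein deacetylase HDAC6 (Homo sapiens), read by fluorescence, with a stated time of 40 min, tested at 100 nM (on this read-out lower numbers stand for less inhibition and higher numbers for more inhibition at the one concentration tested (going by the name of the read-out)), compound 1 stands highest of the three numbers; compound 2 lies beyond the scatter below it, and compound 3 lies beyond the scatter below it as well. Within the data shown here, the only measured single-place step is a number 4 percentage points lower from compound 2 to compound 3 (within the scatter), which concerns the group on the carbonyl carbon and not the aryl group, so it does not bear on the change considered here. Compound 4 `O=C(NO)c1ccc(NCc2nc(-c3cc4ccccc4s3)nn2-c2ccccc2)cc1` differs from compound 1 by 1-benzothiophen-2-yl in place of pyridin-3-yl on an aromatic carbon. Among the measured compounds shown here, no measured step covers an aryl exchange at this place, while the hydroxy on the carbonyl carbon of compound 1 is kept. The step is therefore expected to be none beyond the scatter: a number 2.7 percentage points lower from compound 1 to compound 4 (within the scatter). Compound 4 is estimated at 55%, within 30% to 80%.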

Compound 4, a percentage reported as inhibition, at one concentration (the size of the read-out at that concentration, not a potency): 65.5%
Compound 4: the middle estimate sits 10.5 percentage points below what was measured; the range from low to high includes it.
By their numbers in this assay, from the lowest: compounds 3 and 2 (each within the scatter of the next); then compounds 1 and 4 (each within the scatter of the next).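

this assay gives a first reading of an aryl exchange at this place, with the hydroxy on the carbonyl carbon kept: 1-benzothiophen-2-yl in place of pyridin-3-yl gives a number 7.8 percentage points higher from compound 1 to compound 4 (within the scatter), so a group of 9 heavy atoms without a ring nitrogen stands here in place of one of 6 heavy atoms with no change beyond the scatter. Nothing at hand accounts for this result. Still open, from the compounds shown here alone, is how this place responds to a non-aromatic group, such as cyclohexyl, a longer alkyl chain or an amine.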